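The source may hold more compounds than are shown below. What is called first, only, known or untested is meant among the compounds shown, and "the series" means these compounds.

In an ADME assay on cells (Homo sapiens) for cytotoxicity, read by resazurin assay, with a stated time of 5 days (on this read-out higher numbers stand for lower toxicity in this test and lower numbers for higher toxicity in this test), compound 3 `O=S(=O)(Cc1nc(-c2ccc(Cl)nc2)c2sccc2n1)c1cccc(Cl)c1` gives 70000 nM, within the scatter of compound 1 `COc1ccc(Nc2nc(CS(=O)(=O)c3cccc(Cl)c3)nc3ccsc23)cc1` at 60000 nM. Compound 2 `COc1ccc(-c2nc(CSCc3cccc(Cl)c3)nc3ccsc23)cn1` reads > 50000 nM, which is a limit of the assay and not a number. The next structure, compound 4 `COc1ccc(-c2nc(CS(=O)(=O)c3cccc(Cl)c3)nc3ccsc23)cc1`, carries 4-methoxyphenyl in place of 6-chloropyridin-3-yl on an aromatic carbon. For the measured compounds named here, one measured step bears on this exchange, the replacement of (4-methoxyphenyl)amino by 6-chloropyridin-3-yl, and it is small: a 1.2-fold higher number from compound 1 to compound 3 (0.07 log units; within the scatter). Going by the values given here, with only that step as a guide, no change beyond the scatter is expected, in either direction. The expected change is a 1.1-fold lower number from compound 3 to compound 4 (0.03 log units; within the scatter). For compound 4 the estimated value is 65000 nM, with an expected range from 35000 nM to 100000 nM.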

Compound 4, half-maximal cytotoxic concentration: 69000 nM
Compound 4: the middle estimate sits 1.1-fold (0.03 log units) below what was measured; the measured number falls inside the stated range.
By their numbers in this assay, from the lowest: compounds 1, 4 and 3 (each within the scatter of the next).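

In this assay, two aromatic groups on this carbon next to the ring nitrogen are now compared directly, and the exchange gives a 1.0-fold lower number from compound 3 to compound 4 (0.01 log units; within the scatter). The same 4-methoxyphenyl with and without its amino link gives a 1.2-fold higher number from compound 1 to compound 4 (0.06 log units; within the scatter). All three groups at this place, in compounds 1, 3 and 4, therefore read alike within the scatter in this test.

As far as these compounds go, whether an aliphatic amine such as morpholine or a carboxylic acid at this place would depart from these readings remains open. Nothing given here accounts for this sameness.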